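Replacing an isobutyl chain with a small oxygen ring

The source may report more compounds than this note shows. Statements on the series, on what has been measured and on what is new or still open speak of the compounds shown alone.

Of the compounds shown here, two built on a shared core have been tested in a functional assay on A549 cells (Homo sapiens) for inhibition, read by sulforhodamine B assay, with a stated time of 48 h; a lower number here means a stronger inhibitor, a higher number a weaker inhibitor. Compound 1 `COc1cc2c(cc1CC=C(C)C)/C(=N/O)C[C@@H](c1ccc(O)cc1)O2` gives 11400 nM in this assay. Compound 2 `COc1cc2c(cc1CCC(C)C)C(=O)C[C@@H](c1ccc(O)cc1)O2` gives 30500 nM in this assay, the higher of the two numbers shown, and its gap to compound 1 lies beyond the ordinary scatter of repeated runs, so compound 2 is the weaker inhibitor of the pair.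

Compound 3 `COc1cc2c(cc1CC1OC1(C)C)C(=O)C[C@@H](c1ccc(O)cc1)O2` has not been measured yet. It differs from compound 2 in one place: 3,3-dimethyloxiran-2-yl in place of isobutyl on a saturated chain carbon bound to an aromatic carbon. Nothing in the measured pair speaks directly to this kind of exchange, since compound 1 and compound 2 differ from each other at more than one point.

Within the data shown here, with no comparable step to lean on, the expectation for compound 3 rests on compound 2 alone, whose value of 30500 nM serves as the anchor. The step from compound 2 to compound 3 in this assay is expected to be a 1.5-fold lower number from compound 2 to compound 3 (0.18 log units; within the scatter), a shift toward a lower number that is not clearly beyond the scatter. Compound 3 is therefore estimated at 20000 nM in this assay, with a plausible range from 8000 nM to 60000 nM.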

Compound 3, half-maximal inhibitory concentration: 29800 nM
Estimate against measurement, compound 3: 1.5-fold (0.17 log units) below; the range from low to high includes it.
By their numbers in this assay, from the lowest: compound 1; then compounds 3 and 2 (each within the scatter of the next).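

In this assay, among these compounds, exchanging isobutyl for 3,3-dimethyloxiran-2-yl on a saturated chain carbon bound to an aromatic carbon gives a 1.0-fold lower number from compound 2 to compound 3 (0.01 log units; within the scatter), the first direct reading of a single change at this place. The entering group brings one more heavy atom, an oxygen, a three-membered ring and a hydrogen-bond acceptor, yet compound 2 and compound 3 cannot be told apart in this read-out, so at this place the assay does not separate the open carbon chain from the small oxygen ring. Nothing measured here offers a reason for this match.

As far as these compounds go, a single exchange cannot show whether this place tolerates change in general, and it remains open whether an amine, a carboxylic acid or a longer chain in the same spot would move the number beyond the scatter. Compound 2 differs from compound 1 at more than one point, so the value of compound 1, 11400 nM, cannot be tied to any one change and adds nothing about this exchange.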